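Adding a Fluoro Group to Compound 2

A few compounds are considered here, and "the series" means these few. Any claim that something is new, unique, unknown or untested is made for them only; others in the source may bear on it.

Within the data shown here, compound 2 `COc1cc(/C=C/C(=O)c2sc(Nc3cccc(Cl)c3)nc2C)cc(OC)c1OC` is the only member of this small series with a numerical reading: in a functional assay on BGC-823 cells (Homo sapiens) for cytotoxicity, read by MTT assay (a lower number here means a stronger inhibitor, a higher number a weaker inhibitor), compound 2 gives 11600 nM. The two companions sit at the assay limit. Compound 1 `Cc1ccccc1Nc1nc(C)c(C(=O)/C=C/c2ccc(Cl)cc2)s1` reaches only the limit of this assay, reported as > 25000 nM. Compound 3 `Cc1ccccc1Nc1nc(C)c(C(=O)/C=C/c2ccccc2)s1` likewise gives no number in this assay, only the limit > 25000 nM. Among the measured compounds shown here, the single measured step, a step that the two limits leave unreadable from compound 1 to compound 3, is therefore unreadable, because the limit of > 25000 nM in this assay, at which 2 of the 3 values shown sit, hides any change hydrogen in place of chloro might have caused.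

Compound 4 `COc1cc(/C=C/C(=O)c2sc(Nc3ccc(F)c(Cl)c3)nc2C)cc(OC)c1OC` differs from compound 2 by fluoro in place of hydrogen on an aromatic carbon, turning the (3-chlorophenyl)amino arm into a (3-chloro-4-fluorophenyl)amino arm. For the measured compounds named here, no measured step in this set involves fluoro, and the one step on the same aromatic ring is unreadable, so nothing here points to a change in either direction. Compound 4 is thus expected to stay close to compound 2, with an estimated value of 11000 nM, ranging from 4000 nM to 30000 nM. The expected step, a 1.1-fold lower number from compound 2 to compound 4 (0.02 log units; within the scatter), lies within the usual scatter, with some chance that only a limit is returned.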

Compound 4, half-maximal inhibitory concentration: 9700 nM
Estimate against measurement, compound 4: 1.1-fold (0.05 log units) above; measured number inside the range.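

In this assay, fluoro in place of hydrogen on an aromatic carbon gives the series its first readable step, a 1.2-fold lower number from compound 2 to compound 4 (0.08 log units; within the scatter), so this position, ortho to a chloro group and para to a large group, accepts a fluoro group without a change that can be told from the scatter. Among these compounds, the only earlier step on an aromatic ring cannot be read, whereas compound 2 and compound 4 both return numbers, which leaves this pair clear of the obstacle that hid that step: the limit of > 25000 nM in this assay, at which 2 of the 4 values shown sit. The finding remains narrow, since it covers one replacement at one place, made on the 3-chlorophenyl arm of compound 2 alone.

As far as these compounds go, whether a methoxy group, a trifluoromethyl group or an amine at this same place would also leave the reading unchanged stays open. Equally open, from the compounds shown here alone, is whether a fluoro group would bring any numerical reading on the arm of compound 3, where the assay returns only a limit, > 25000 nM.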